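Adding a second methoxy to compound 2

A few compounds are considered here, and "the series" means these few. Any claim that something is new, unique, unknown or untested is made for them only; others in the source may bear on it.

Measured compounds:
Compound 2, `COc1ccc(N/C=C\C(=O)c2nc(-c3ccc(F)cc3)n3ccccc23)cc1`: in a functional assay on B16-F10 cells (Mus musculus) for cytotoxicity, read by MTT assay, with a stated time of 48 h (on this read-out higher numbers stand for weaker inhibition and lower numbers for stronger inhibition), compound 2 gives 2560 nM.
Compound 1, `COc1ccc(N/C=C\C(=O)c2nc(-c3ccc(C(F)(F)F)cc3)n3ccccc23)cc1OC`: in this assay compound 1 gives only a limit, > 30000 nM.

Going by the values given here, compound 2 stands as the only numbered value shown; compound 1 sits at the limit (the limit of > 30000 nM in this assay, at which 1 of the 2 values shown sits). Compound 3, `COc1ccc(N/C=C\C(=O)c2nc(-c3ccc(F)cc3)n3ccccc23)cc1OC`, differs from compound 2 by methoxy in place of hydrogen on an aromatic carbon. No step between measured compounds is shown, so the size of this change is untested here. Compound 3 is expected to be weaker than compound 2 in this assay, with the step of a 3.1-fold higher number from compound 2 to compound 3 (0.49 log units; beyond the scatter) lying beyond the scatter. Compound 3 is estimated at 8000 nM, within 2500 nM to 30000 nM.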

Compound 3, half-maximal inhibitory concentration: > 30000 nM
Compound 3 gave a limit, no number; the forecaster's own chance of this, stated with the estimate: 30%; middle value at least 3.7-fold (0.57 log units) from the limit.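

In this assay, the methoxy alone, placed ortho to a methoxy group, gives an at least 11-fold higher number from compound 2 to compound 3 (1.06 log units; beyond the scatter), a step that rests on a limit for compound 3 rather than a number. Going by these compounds alone, compound 1 differs from compound 2 in two places, so only this pair isolates the change from 4-methoxyphenyl to 3,4-dimethoxyphenyl. Compound 3 joins compound 1 at the limit: the limit of > 30000 nM in this assay, at which 2 of the 3 values shown sit.

From the compounds shown here alone, the step between those two limits cannot be read, so any effect of fluoro against trifluoromethyl stays unknown. Going by these compounds, whether a hydroxy or a chlorine at this position would be tolerated also stays open.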